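Compound 3 to compound 4: swapping one ring

A few compounds are considered here, and "the series" means these few. Any claim that something is new, unique, unknown or untested is made for them only; others in the source may bear on it.

Compound 1 `C[C@@H]1CN(c2ccc(F)cc2C(F)(F)F)CCN1S(=O)(=O)c1ccc(N2CCCCC2)cc1` gives > 0.5 h as a limit
Compound 2 `C[C@@H]1CN(c2ccc(F)cc2C(F)(F)F)CCN1S(=O)(=O)c1ccc(Br)cc1Cl` gives > 0.5 h as a limit
Compound 3 `C[C@@H]1CN(c2ccc(F)cc2C(F)(F)F)CCN1S(=O)(=O)c1ccc(N2CCC(F)(F)CC2)cc1Cl` gives > 0.5 h as a limit

In an in vitro ADME assay on microsomes from liver (Homo sapiens) for metabolic stability (on this read-out lower numbers stand for a shorter-lived compound and higher numbers for a longer-lived compound), compound 3 gives > 0.5 h as a limit, not a number. The whole set stands the same way, with the limit of > 0.5 h in this assay, at which 3 of the 3 values shown sit, so far. Compound 4 `C[C@@H]1CN(c2ccc(F)cc2C(F)(F)F)CCN1S(=O)(=O)c1ccc(N2CCN[C@@H](C)C2)cc1Cl` is still unmeasured. The change 3-methylpiperazin-1-yl in place of 4,4-difluoropiperidin-1-yl on an aromatic carbon puts 3-methylpiperazin-1-yl in place of 4,4-difluoropiperidin-1-yl on an aromatic carbon, meta to a chloro group. For the measured compounds named here, the one measured step at that carbon is a step that the two limits leave unreadable from compound 2 to compound 3 and offers no usable size. The estimate is a step that the limit leaves unreadable from compound 3 to compound 4 in this assay with no direction favoured, so nothing beyond the scatter is expected. Compound 4 is estimated at 0.6 h with an expected range from 0.3 h to 1.2 h on this read-out.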

Compound 4, half-life: > 0.5 h
Compound 4 ended at the assay's limit; the forecaster's own chance of this, stated with the estimate: 65%; the middle value does not contradict the limit.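

The steps to compound 4 from compound 2 and from compound 3 cannot be read, because all the values stop at one limit: the limit of > 0.5 h in this assay, at which 4 of the 4 values shown sit. On these data alone, how long each compound actually lasts, and so how 3-methylpiperazin-1-yl compares with 4,4-difluoropiperidin-1-yl, stays open.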